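Changing the amide end of a naphthyl-pyridine compound

The compounds below may be only part of what the source reports. "The series", "measured", "known", "first", "only" and "open" are said of these compounds alone.

Measured compounds:
compound 1 `CNC(=O)/C=C/c1ccncc1-c1ccc2ccccc2c1` gives 101%
compound 2 `O=C(O)COc1ccncc1-c1ccc2ccccc2c1` gives 16%

In an assay on a protein complex for inhibition of CDK8/Cyclin C (Homo sapiens), with a stated time of 1 h, tested at 10 uM (on this read-out lower numbers stand for less inhibition and higher numbers for more inhibition at the one concentration tested (going by the name of the read-out)), compound 1 gives 101%, the higher of the two numbers measured. Compound 2 sits far lower: the step of a number 85 percentage points lower from compound 1 to compound 2 (beyond the scatter) comes with carboxymethoxy in place of 2-(methylcarbamoyl)ethenyl on an aromatic carbon, so the whole side chain was exchanged.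

Compound 3 `COC1CN(C(=O)/C=C/c2ccncc2-c2ccc3ccccc3c2)C1` keeps that side chain and differs from compound 1 only at its far end: 3-methoxyazetidin-1-yl in place of methylamino on a carbonyl carbon.

For the measured compounds named here, no measured pair bears directly on this change; the single step known swaps the entire chain, not just the amide end. The shared core and the chain carrying the carbonyl stay in place, so compound 3 is expected to remain near compound 1, with a step of a number 13 percentage points lower from compound 1 to compound 3 (beyond the scatter) not clearly beyond the scatter. Compound 3 is therefore estimated at 88%, in a range from 55% to 105%.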

Compound 3, a percentage reported as inhibition, at one concentration (the size of the read-out at that concentration, not a potency): 100%
The estimate for compound 3 lay 12 percentage points below the measured number; measured number inside the range.
By their numbers in this assay, from the lowest: compound 2; then compounds 3 and 1 (each within the scatter of the next).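

In this assay, the swap of methylamino for 3-methoxyazetidin-1-yl on the carbonyl carbon gives a step of a number 1 percentage points lower from compound 1 to compound 3 (within the scatter), so this end of the chain accepts a clearly larger group with no measurable effect on the number. The change removes the amide hydrogen, taking the count of hydrogen-bond donors in this group from 1 to 0, and adds a four-membered ring, yet the read-out at this one concentration does not register it.

A carboxylic acid on the same chain, in place of the amide, would show whether the low number for compound 2 goes with the acid or with the loss of the chain. On these data alone, whether a larger ring such as piperidine or a charged amine is accepted at this end also stays open.

Nothing measured here explains why this end accepts the change.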